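The source may report more compounds than this note shows. Statements on the series, on what has been measured and on what is new or still open speak of the compounds shown alone.

Compound 1 `COC(=O)[C@@]1(C)CCC=C2[C@@H]1CC[C@@H](C)[C@]2(C)Cc1c[nH]c2c(Br)cccc12` and compound 2 `COC(=O)[C@@]1(C)CCC=C2[C@@H]1CC[C@@H](C)[C@]2(C)Cc1c[nH]c2c(Cl)cccc12` share one core, while compound 3 `COC(=O)[C@@]1(C)CC[C@@H]2C3=C1CC[C@@H](C)[C@]3(C)C[C@@H]1c3cccc(Br)c3N[C@H]21` and compound 4 `COC(=O)[C@@]1(C)CC[C@@H]2C3=C1CC[C@@H](C)[C@]3(C)C[C@@H]1c3cccc(Cl)c3N[C@H]21` share another; compound 3 has the same atoms as compound 1, joined differently, and the difference between the two cores is not broken down here. In a functional assay on T47D cells (Homo sapiens) for inhibition, read by sulforhodamine B assay, with a stated time of 48 h (a higher number here means a weaker inhibitor of growth, a lower number a stronger inhibitor of growth), compound 1 gives 24000 nM and compound 2 gives 24000 nM. The change between them, (chloro in place of bromo on an aromatic carbon), produced no change at the digits printed from compound 1 to compound 2 (within the scatter). In this assay compound 3 gives 37000 nM, a value that sits within the scatter of both compound 1 and compound 2. Compound 4 arises from compound 3 by the same kind of change, (chloro in place of bromo on an aromatic carbon); the aromatic ring that carries the halogen is here part of a fused or bridged system of five rings rather than of two. The step from compound 3 to compound 4 is expected to be no change at the digits printed from compound 3 to compound 4 (within the scatter), because no change at the digits printed from compound 1 to compound 2 (within the scatter) came from the same swap of halogens. On that basis compound 4 in this assay is estimated to give 37000 nM, most likely between 18000 nM and 75000 nM.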

Compound 4, concentration for 50% growth inhibition: 50000 nM
Beside the measured number, compound 4's estimate is 1.4-fold (0.13 log units) below it; the range from low to high includes it.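

Replacing bromo with chloro on an aromatic carbon gives a 1.4-fold higher number from compound 3 to compound 4 (0.13 log units; within the scatter) in this assay, and this step can be set beside the same replacement on the other core: the same change on two cores in this assay, no change at the digits printed (within the scatter) from compound 1 to compound 2 and a 1.4-fold higher number (0.13 log units; within the scatter) from compound 3 to compound 4, 1.4-fold (0.13 log units) apart, within the scatter of two such steps

Within this small set, the replacement therefore carries over from one core to the other, in the sense that bromo and chloro cannot be told apart in this assay on either core. Within the data shown here, this rests on only two pairs of compounds, however, so a small real difference between the cores could stay hidden in the scatter, and nothing here shows how any other change would carry over.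

The compounds shown have only bromo or chloro at this place, so it remains open whether fluoro, methyl or an amine there would shift growth inhibition beyond the scatter on either core. Going by these compounds, it also remains open whether a carboxylic acid or an amide in place of the methyl ester would behave alike on the two cores.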